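Adding Fluorine Where It Earlier Made No Difference

The source may hold more compounds than are shown below. What is called first, only, known or untested is meant among the compounds shown, and "the series" means these compounds.

Compound 1 `c1ccc(-c2ccc(-c3ccc(-c4nc5ccccc5[nH]4)cc3)cc2)cc1` is the simplest member of this small set. In a functional assay on ZR-75-1 cells (Homo sapiens) for inhibition, read by sulforhodamine B assay (on this read-out lower numbers stand for stronger inhibition of growth and higher numbers for weaker inhibition of growth), compound 1 gives 100000 nM. Compound 2 `Fc1ccc(-c2ccc(-c3ccc(-c4nc5ccccc5[nH]4)cc3)cc2)cc1` differs from compound 1 by one change, (fluoro in place of hydrogen on an aromatic carbon), and in this assay compound 2 gives 100000 nM; the step of no change at the digits printed from compound 1 to compound 2 (within the scatter) shows that this change left the read-out as it was. Compound 3 `Cc1ccc2[nH]c(-c3ccc(-c4ccc(-c5ccccc5)cc4)cc3)nc2c1` carries a different change on the shared core, (methyl in place of hydrogen on an aromatic carbon), and in this assay compound 3 gives 27400 nM; the step of a 3.6-fold lower number from compound 1 to compound 3 (0.56 log units; beyond the scatter) is a real, if modest, improvement, and compound 3 therefore stands at the lowest number of the three.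

Compound 4 `Cc1ccc2[nH]c(-c3ccc(-c4ccc(-c5ccc(F)cc5)cc4)cc3)nc2c1` has not yet been measured. It differs from compound 3 by fluoro in place of hydrogen on an aromatic carbon, which is the same change that turns compound 1 into compound 2, made at a place described in the same words. The two cores differ by the change described under (methyl in place of hydrogen on an aromatic carbon), the methyl that compound 3 and compound 4 share and compound 1 and compound 2 lack.

Within the data shown here, the expectation for compound 4 rests on the one earlier example of this change: the step of a 1.0-fold lower number from compound 3 to compound 4 (0.01 log units; within the scatter) is estimated to be small because the same change gave no change at the digits printed from compound 1 to compound 2 (within the scatter). Accordingly compound 4 is expected to give about 27000 nM in this assay, most likely between 12000 nM and 60000 nM. Among the measured compounds shown here, only two examples of this change exist here, so the estimate is uncertain.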

Compound 4, concentration for 50% growth inhibition: 35000 nM
Compound 4: middle estimate off by 1.3-fold (0.11 log units), on the low side; the range from low to high includes it.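

In this assay, the change from phenyl to 4-fluorophenyl again leaves the read-out where it was, with a 1.3-fold higher number from compound 3 to compound 4 (0.11 log units; within the scatter), and this agrees with the same change on the core without the methyl: the same change on two cores in this assay, no change at the digits printed (within the scatter) from compound 1 to compound 2 and a 1.3-fold higher number (0.11 log units; within the scatter) from compound 3 to compound 4, 1.3-fold (0.11 log units) apart, within the scatter of two such steps. The methyl change also carries over, giving a 2.9-fold lower number from compound 2 to compound 4 (0.46 log units; beyond the scatter), a modest step that matches the one seen on the core without the fluoro: the same change on two cores in this assay, a 3.6-fold lower number (0.56 log units; beyond the scatter) from compound 1 to compound 3 and a 2.9-fold lower number (0.46 log units; beyond the scatter) from compound 2 to compound 4, 1.3-fold (0.11 log units) apart, within the scatter of two such steps. Across these four compounds, then, each change has much the same size whether or not the other is present, but this rests on only two examples of each change, with one group at one place, and it neither explains the pattern nor shows that it would hold for other groups or places.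

As far as these compounds go, it remains open whether a chloro or a methoxy in place of the fluoro would also leave the read-out unchanged. From the compounds shown here alone, it also remains open whether an ethyl, a longer chain, an amine or a carboxylic acid in place of the methyl would give a step of similar size, or whether such a step would carry from one core to the other as these two changes do.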